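This account rests on a few compounds, and the source may have more. Where it says the series, first, only, none or still open, it means among the compounds named here.

Compound 1 `COc1cc(-c2nccn2C(C)C)cc(OC)c1OC` carries an isopropyl group on an aromatic nitrogen of its five-membered ring. In a functional assay on MDA-MB-468 cells (Homo sapiens) for antiproliferative activity, read by MTT assay, with a stated time of 72 h (on this read-out lower numbers stand for stronger inhibition and higher numbers for weaker inhibition), compound 1 gives only a limit, > 100000 nM, and no number. Compound 1 therefore stands at the weak end of what has been measured here. Compound 2 `COc1cc(-c2nccn2-c2ccc3cc[nH]c3c2)cc(OC)c1OC`, which carries a different group on that nitrogen, gives in this assay 1700 nM. The evidence on the measured values amounts to one point: the limit of > 100000 nM in this assay, at which 1 of the 2 values shown sits.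

Compound 3 `COc1ccc(-n2ccnc2-c2cc(OC)c(OC)c(OC)c2)cc1` has not yet been measured. It differs from compound 1 in one place: 4-methoxyphenyl in place of isopropyl on an aromatic nitrogen. Compound 2 already shows what an aromatic group on that nitrogen goes with, namely 1700 nM in this assay. Going by the values given here, no measured step exists for this exact change, so the expectation rests on these two values alone. The step from compound 1 to compound 3 is expected to be large and toward stronger inhibition, estimated as an at least 33-fold lower number from compound 1 to compound 3 (1.52 log units; beyond the scatter), well beyond the usual scatter. Compound 3 is accordingly estimated to give in this assay 3000 nM, with a range from 500 nM to 30000 nM.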

Compound 3, half-maximal inhibitory concentration: 500 nM
Compound 3: middle estimate off by 6.0-fold (0.78 log units), on the high side; the measured number falls inside the stated range.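

Swapping isopropyl for 4-methoxyphenyl on the aromatic nitrogen gives an at least 200-fold lower number from compound 1 to compound 3 (2.30 log units; beyond the scatter) in this assay, the first measured step at this position, and it shows that this one change can carry a large shift on the shared core. Compound 3 gives 500 nM and compound 2 gives 1700 nM, so two different aromatic groups on this nitrogen now return measured numbers, whereas the isopropyl group of compound 1 does not. Compound 1 is held only by a limit and not by a number, so the step is open-ended on its weak side: the limit of > 100000 nM in this assay, at which 1 of the 3 values shown sits.

The compounds shown leave open whether the methoxy group of 4-methoxyphenyl matters, as neither an unsubstituted phenyl ring nor a 4-chlorophenyl or 4-aminophenyl group appears among them to separate the ring from its substituent. They also leave open whether a ring has to be aromatic to give a measured number in this assay, or whether a saturated ring such as cyclohexyl, a benzyl group or a longer chain such as n-butyl on the same nitrogen would do the same.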